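Phenyl for pyridinyl on the piperazine series

This account rests on a few compounds, and the source may have more. Where it says the series, first, only, none or still open, it means among the compounds named here.

compound 1 `Nc1ccccc1NC(=O)c1ccc(CSC(=S)N2CCc3cc([N+](=O)[O-])ccc32)cc1`: 26.8%
compound 2 `Nc1ccccc1NC(=O)c1ccc(CSC(=S)N2CCc3ccc([N+](=O)[O-])cc32)cc1`: 30.6%
compound 3 `Nc1ccccc1NC(=O)c1ccc(CSC(=S)N2CCN(c3ccncc3)CC2)cc1`: 64.8%

Three compounds of this series have been run in a functional assay on MGC-803 cells (Homo sapiens) for antiproliferative activity, read by CCK-8 assay, with a stated time of 72 h, tested at 2 uM; on this read-out higher numbers stand for a stronger effect at the one concentration tested and lower numbers for a weaker effect. Compound 1, with structure `Nc1ccccc1NC(=O)c1ccc(CSC(=S)N2CCc3cc([N+](=O)[O-])ccc32)cc1`, gives 26.8% in this assay. Compound 2, with structure `Nc1ccccc1NC(=O)c1ccc(CSC(=S)N2CCc3ccc([N+](=O)[O-])cc32)cc1`, gives 30.6%. Compound 3, with structure `Nc1ccccc1NC(=O)c1ccc(CSC(=S)N2CCN(c3ccncc3)CC2)cc1`, gives 64.8%, the highest of the three numbers; its gap to compound 2 and its gap to compound 1 both lie beyond the usual scatter of repeated measurements, so compound 3 is the strongest of the measured set in this assay.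

The next compound, compound 4 `Nc1ccccc1NC(=O)c1ccc(CSC(=S)N2CCN(c3ccccc3)CC2)cc1`, keeps the whole skeleton of compound 3 and differs from it in one place: phenyl in place of pyridin-4-yl on an amine nitrogen in a ring. For the measured compounds named here, no measured pair in the set shows this change, so its size is not known from the data.

Compound 4 is expected to stay close to compound 3, with a step of a number 9.8 percentage points lower from compound 3 to compound 4 (within the scatter) expected to be small, perhaps a modest fall that may or may not reach beyond the scatter. Compound 4 is therefore estimated at 55% in this assay, within a range of 35% to 75%.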

Compound 4, a percentage reported as inhibition, at one concentration (the size of the read-out at that concentration, not a potency): 42.3%
The estimate for compound 4 lay 12.7 percentage points above the measured number; the measured number falls inside the stated range.
By their numbers in this assay, from the lowest: compounds 1 and 2 (each within the scatter of the next); then compound 4; then compound 3.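

For the compounds shown here, replacing pyridin-4-yl with phenyl on an amine nitrogen in a ring gives, in this assay, a number 22.5 percentage points lower from compound 3 to compound 4 (beyond the scatter), and this is the first step in the set between two compounds that differ in one place. The two groups have the same count of heavy atoms and are both six-membered aromatic rings, and what separates them is a single ring nitrogen, with its one hydrogen-bond acceptor, exchanged for carbon; that exchange alone is enough to move the read-out beyond the scatter at this position. The data shown give no measurement that would account for this fall.

Going by these compounds, what a pyridin-3-yl or pyrimidin-2-yl group would give on the same nitrogen remains open, as does whether a phenyl bearing an amine or a carboxylic acid would regain or lose further ground from the level of compound 4. On these data alone, it also remains open whether the size of this step would hold at other concentrations, since each number here is the size of the read-out at a single concentration and not a potency.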